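Trimming a Ring to a Branched Chain at the Core

This account rests on a few compounds, and the source may have more. Where it says the series, first, only, none or still open, it means among the compounds named here.

Compound 1 `Nc1cc(C2CCCC2)nc2ccc(NC(=O)/C=C/c3ccc(C(F)(F)F)cc3)cc12` is the reference here. In an assay on isolated protein for displacement of a labelled ligand from melanin-concentrating hormone receptor 1 (Homo sapiens) (on this read-out higher numbers stand for weaker inhibition and lower numbers for stronger inhibition), compound 1 gives 0.8 nM, the lowest of the three numbers measured. Going by the values given here, compound 2 `CCCc1cc(N)c2cc(NC(=O)/C=C/c3ccc(F)cc3)ccc2n1` gives 130 nM, and compound 3 `CCCc1cc(N)c2cc(NC(=O)/C=C/c3ccc(Cl)cc3)ccc2n1` gives 6 nM; the one recorded step, a 22-fold lower number from compound 2 to compound 3 (1.34 log units; beyond the scatter), concerns the halogen on the distant aromatic ring, not the group next to the ring nitrogen. Compound 4 `CC(C)c1cc(N)c2cc(NC(=O)/C=C/c3ccc(C(F)(F)F)cc3)ccc2n1` differs from compound 1 by isopropyl in place of cyclopentyl on an aromatic carbon. Among the compounds with values here, no measured step touches this position, so the expectation rests on compound 1 alone. A modest loss is expected, a 2.5-fold higher number from compound 1 to compound 4 (0.40 log units; beyond the scatter), since the smaller isopropyl group may not fully match the cyclopentyl. Compound 4 is therefore estimated at 2 nM, within a range of 0.5 nM to 8 nM.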

Compound 4, half-maximal inhibitory concentration: 2.1 nM
For compound 4 the middle estimate is 1.1-fold (0.02 log units) below the measured one, within the range that was stated.
By their numbers in this assay, from the lowest: compound 1; then compound 4; then compound 3; then compound 2.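

Going by these compounds alone, replacing cyclopentyl with isopropyl next to the ring nitrogen gives a 2.6-fold higher number from compound 1 to compound 4 (0.42 log units; beyond the scatter), the first measured change at this position. The step is modest and beyond the scatter, so the five-membered ring is not essential for strong inhibition, although its removal costs some inhibition, with compound 4 still at 2.1 nM. Nothing available here accounts for this small loss.

From the compounds shown here alone, it remains open how smaller or larger groups, such as methyl or cyclohexyl, would behave at this position on the same core. An amine-bearing chain there is equally unresolved.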